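The source may hold more compounds than are shown below. What is called first, only, known or untested is meant among the compounds shown, and "the series" means these compounds.

In an ADME assay on the whole organism for metabolic stability, with Rattus norvegicus as the target, given by the intravenous route (on this read-out lower numbers stand for a shorter-lived compound and higher numbers for a longer-lived compound), compound 1 `CCNC(=O)Nc1nc2cc(-c3cccnc3)cc(-c3ccccn3)c2[nH]1` gives 2.1 h, and compound 2 `CCNC(=O)Nc1nc2cc(-c3cccnc3)cc(-c3ncccc3F)c2[nH]1` gives 0.7 h, the lower of the two numbers; the step of a 3.0-fold lower number from compound 1 to compound 2 (0.48 log units; beyond the scatter) came from a fluoro in place of hydrogen. Compound 3 `CCNC(=O)Nc1nc2cc(-c3cnc(C(C)(C)O)nc3)cc(-c3ncccc3F)c2[nH]1` differs from compound 2 by 2-(1-hydroxy-1-methylethyl)pyrimidin-5-yl in place of pyridin-3-yl on an aromatic carbon, a change of a different kind: neither measured step bears on it, so no shift beyond the scatter is expected, though the range is wide. Compound 3 is estimated at 0.8 h in this assay, between 0.3 h and 2.2 h, meaning an expected step of a 1.1-fold higher number from compound 2 to compound 3 (0.06 log units; within the scatter).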

Compound 3, half-life: 1.2 h
Beside the measured number, compound 3's estimate is 1.5-fold (0.18 log units) below it, within the range that was stated.
By their numbers in this assay, from the lowest: compounds 2, 3 and 1 (each within the scatter of the next, the first and the last beyond it).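

In this assay, replacing pyridin-3-yl with the larger 2-(1-hydroxy-1-methylethyl)pyrimidin-5-yl gives a 1.7-fold higher number from compound 2 to compound 3 (0.23 log units; within the scatter), so these two groups cannot be told apart on this read-out. Among these compounds, this is the first sign that this position, unlike the site of the fluoro change, can take a substantial swap without a shift beyond the scatter. No measurement shown here offers an explanation for this result. As far as these compounds go, it remains open whether a plain pyrimidin-5-yl ring would behave the same way without the hydroxy-bearing chain, and whether an amine or a carboxylic acid at this position would move the half-life beyond the scatter.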